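Hydrazone aryl swap: hydroxy out, methoxy in

The compounds below may be only part of what the source reports. "The series", "measured", "known", "first", "only" and "open" are said of these compounds alone.

Among the compounds with values here, compound 3 `O=C(N/N=C/c1cccc(O)c1)c1cccnc1Nc1cccc(C(F)(F)F)c1` carries the highest of the three numbers so far in a functional assay on the whole organism (strain Wistar) for inhibition, with Rattus norvegicus as the target, read by paw edema, with a stated time of 30 min, at a dose of 10 mg/kg by the intraperitoneal route (on this read-out higher numbers stand for more inhibition at the one dose given (going by the name of the read-out) and lower numbers for less inhibition), giving 67.5%. Compound 1 `O=C(N/N=C/c1ccccc1)c1cccnc1Nc1cccc(C(F)(F)F)c1` gives 60.4%, and compound 2 `O=C(N/N=C/c1ccc(Cl)cc1)c1cccnc1Nc1cccc(C(F)(F)F)c1` gives 52.4%. Within the data shown here, only the step of a number 15.1 percentage points higher from compound 2 to compound 3 (beyond the scatter) lies beyond the scatter; a number 7.1 percentage points higher from compound 1 to compound 3 (within the scatter) and a number 8 percentage points lower from compound 1 to compound 2 (within the scatter) both stay within it, so compound 3 and compound 1 cannot be ranked against each other.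

Compound 4 `COc1ccc(/C=N/NC(=O)c2cccnc2Nc2cccc(C(F)(F)F)c2)cc1` is the next member, differing from compound 3 by 4-methoxyphenyl in place of 3-hydroxyphenyl on a carbon with a double bond to nitrogen. Among the measured compounds shown here, two measured steps bear on it. The step of a number 7.1 percentage points higher from compound 1 to compound 3 (within the scatter) shows that hydroxy in place of hydrogen barely moved the read-out, so removing that hydroxy is unlikely to cost much. The step of a number 8 percentage points lower from compound 1 to compound 2 (within the scatter) shows that chloro in place of hydrogen on an aromatic carbon gave a small drop inside the scatter. For the measured compounds named here, no measured pair compares a methoxy group with a hydroxy group, so the anchor is compound 1 at 60.4%. Compound 4 is therefore expected to sit close to compound 1, with a step of a number 9.5 percentage points lower from compound 3 to compound 4 (within the scatter) of modest size downward that may fall within the scatter. The estimate for compound 4 in this assay is 58%, with a range from 45% to 70%.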

Compound 4, a percentage reported as inhibition, in the whole organism at one dose (the size of the read-out at that dose, not a potency): 50.4%
Estimate against measurement, compound 4: 7.6 percentage points above; the measured number falls inside the stated range.
By their numbers in this assay, from the lowest: compounds 4, 2, 1 and 3 (each within the scatter of the next, the first and the last beyond it).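

In this assay, the swap on the carbon with a double bond to nitrogen gives a number 17.1 percentage points lower from compound 3 to compound 4 (beyond the scatter), so compound 3 now stands beyond the scatter from both the 4-methoxyphenyl and the 4-chlorophenyl member, though not from the unsubstituted phenyl of compound 1. Methoxy in place of hydrogen gives a number 10 percentage points lower from compound 1 to compound 4 (within the scatter), and methoxy in place of chloro gives a number 2 percentage points lower from compound 2 to compound 4 (within the scatter), so neither step separates compound 4 from its neighbour and the series offers no ranking among compounds 1, 2 and 4. No measurement at hand accounts for the gap between compound 3 and compound 4.

The swap from 3-hydroxyphenyl to 4-methoxyphenyl alters both the substituent and its printed ring position, so the compounds shown cannot assign the step to either change, and 4-hydroxyphenyl and 3-methoxyphenyl would be the two members that pull them apart. Going by these compounds, how this position responds to an amine or a carboxylic acid on the phenyl also remains open, as does any reading at a dose other than the single one given.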